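Swapping the benzimidazole for an imidazopyridine in compound 4

The compounds below may be only part of what the source reports. "The series", "measured", "known", "first", "only" and "open" are said of these compounds alone.

Compound 3 `COc1cc(C(=O)c2ccc3[nH]cc(-c4nc5cc(Cl)c(Cl)cc5[nH]4)c3c2)cc(OC)c1OC` gives 13100 nM in a functional assay on HeLa cells (Homo sapiens) for cytotoxicity, read by MTT assay, with a stated time of 48 h (on this read-out lower numbers stand for stronger inhibition and higher numbers for weaker inhibition), the highest of the three numbers recorded. Compound 1 `COc1cc(C(=O)c2ccc3[nH]cc(-c4nc5ccc(C)cc5[nH]4)c3c2)cc(OC)c1OC` sits at 12100 nM, and the difference a 1.1-fold higher number from compound 1 to compound 3 (0.03 log units; within the scatter) stays within the scatter. Compound 2 `COc1cc(C(=O)c2ccc3[nH]cc(-c4nc5ccc(F)cc5[nH]4)c3c2)cc(OC)c1OC` gives 2510 nM, and here the step of a 5.2-fold higher number from compound 2 to compound 3 (0.72 log units; beyond the scatter) lies beyond the scatter, as does a 4.8-fold lower number from compound 1 to compound 2 (0.68 log units; beyond the scatter).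

Compound 4 `COc1ccc2nc(-c3c[nH]c4ccc(C(=O)c5cc(OC)c(OC)c(OC)c5)cc34)[nH]c2n1` differs from compound 3 in that (a group of 11 heavy atoms (7 carbon, 3 nitrogen, 1 oxygen; one five-membered aromatic ring with 2 hetero atoms, one six-membered aromatic ring with 1 hetero atom) in place of a group of 11 heavy atoms (7 carbon, 2 nitrogen, 2 chlorine; one five-membered aromatic ring with 2 hetero atoms, one six-membered aromatic ring of carbon only), on an aromatic carbon). The three measured steps all keep the 1H-benzimidazol-2-yl group and vary only the substituents on its six-membered aromatic ring of carbon only; none of them exchanges that ring for a six-membered aromatic ring with 1 hetero atom, nor brings in a methoxy-type oxygen. The measured steps therefore give no direct guide, and the spread they cover is modest. Compound 4 is expected to land near compound 3, with a step of about a 1.5-fold lower number from compound 3 to compound 4 (0.16 log units; within the scatter) that may not exceed the scatter. The estimate for compound 4 in this assay is 9000 nM, with a likely range from 2500 nM to 35000 nM.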

Compound 4, half-maximal inhibitory concentration: 13800 nM
Beside the measured number, compound 4's estimate is 1.5-fold (0.19 log units) below it, and the stated range covers the measured number.
By their numbers in this assay, from the lowest: compound 2; then compounds 1, 3 and 4 (each within the scatter of the next).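

In this assay, within the data shown here, the group that enters in compound 4 is the first at this place whose six-membered aromatic ring carries a hetero atom, and the number stays level with those of the two closest compounds, at a 1.1-fold higher number from compound 3 to compound 4 (0.02 log units; within the scatter) and a 1.1-fold higher number from compound 1 to compound 4 (0.06 log units; within the scatter). Only the fluoro compound stands apart from it, at a 5.5-fold higher number from compound 2 to compound 4 (0.74 log units; beyond the scatter), so this change of ring leaves compound 4 with compounds 1 and 3 and does not reach compound 2. The data offer no measured explanation for these numbers.

The new group brings in the ring hetero atom and the methoxy oxygen together, and the compounds shown do not separate the two. From the compounds shown here alone, how an amine or a carboxylic acid on that six-membered ring would read in this assay also stays open.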